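The source may report more compounds than this note shows. Statements on the series, on what has been measured and on what is new or still open speak of the compounds shown alone.

Three compounds share one core and differ only in a five-membered ring on it. In a physicochemical assay for solubility, at pH 6 (a lower number here means a less soluble compound, a higher number a more soluble compound), compound 1 `N#Cc1ccc(-c2cc(-c3ccc(C(N)=O)cc3)cc(-c3cncs3)n2)cc1` gives 64000 nM, compound 2 `N#Cc1ccc(-c2cc(-c3ccc(C(N)=O)cc3)cc(-c3cnco3)n2)cc1` gives 250000 nM, and compound 3 `Cn1ccnc1-c1cc(-c2ccc(C(N)=O)cc2)cc(-c2ccc(C#N)cc2)n1` gives 8000 nM, the lowest of the three. The ring swaps were not small: an 8.0-fold lower number from compound 1 to compound 3 (0.90 log units; beyond the scatter), and a 31-fold lower number from compound 2 to compound 3 (1.49 log units; beyond the scatter). Compound 4 `Cn1nncc1-c1cc(-c2ccc(C(N)=O)cc2)cc(-c2ccc(C#N)cc2)n1` carries a further change, (1-methyl-1H-1,2,3-triazol-5-yl in place of 1-methyl-1H-imidazol-2-yl on an aromatic carbon). Within the data shown here, no measured step covers this particular ring, so the two earlier swaps show only that exchanging this ring moves the read-out by a modest to large amount. On that basis the step is expected to be a 1.5-fold higher number from compound 3 to compound 4 (0.18 log units; within the scatter), a modest rise in this assay. Compound 4 is therefore estimated at 12000 nM, with a range from 4000 nM to 40000 nM.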

Compound 4, solubility: 32000 nM
Beside the measured number, compound 4's estimate is 2.7-fold (0.43 log units) below it; low and high end bracket the measured number.
By their numbers in this assay, from the lowest: compound 3; then compounds 4 and 1 (each within the scatter of the next); then compound 2.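

In this assay this swap gives a 4.0-fold higher number from compound 3 to compound 4 (0.60 log units; beyond the scatter), so the low number of compound 3 is not shared by the other methylated ring at this position. The 1-methyl-1H-1,2,3-triazol-5-yl group stands close to the 1,3-thiazol-5-yl group, with a 2.0-fold lower number from compound 1 to compound 4 (0.30 log units; within the scatter), and well short of the 1,3-oxazol-5-yl group, with a 7.8-fold lower number from compound 2 to compound 4 (0.89 log units; beyond the scatter), leaving compound 2 the highest of the four. Nothing measured here accounts for these differences. Going by these compounds, whether a five-membered ring carrying an amine or a carboxylic acid at this position would pass the 1,3-oxazol-5-yl group stays open.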